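Replacing 3-Hydroxyphenyl on an Inactive Hydrazone-Type Compound

A few compounds are considered here, and "the series" means these few. Any claim that something is new, unique, unknown or untested is made for them only; others in the source may bear on it.

In a functional assay on A549 cells (Homo sapiens) for antiproliferative activity, read by MTT assay (on this read-out lower numbers stand for stronger inhibition and higher numbers for weaker inhibition), compound 1 `Cc1cc(C)c(/C=N/Nc2ncc3c(n2)n(C2CCCC2)c(=O)c(=O)n3C)c(C)c1` gives 12000 nM. Compound 2 `Cn1c(=O)c(=O)n(C2CCCC2)c2nc(N/N=C/c3cccc(O)c3)ncc21` gives > 100000 nM, which is a limit of the assay and not a number. Compound 2 thus stands at the limit of > 100000 nM in this assay, at which 1 of the 2 values shown sits. For the measured compounds named here, the only measured step is an at least 8.3-fold higher number from compound 1 to compound 2 (0.92 log units; beyond the scatter), with 3-hydroxyphenyl in place of 2,4,6-trimethylphenyl on the same carbon.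

Compound 3 `Cn1c(=O)c(=O)n(C2CCCC2)c2nc(N/N=C/c3ccc(F)cc3Br)ncc21` changes that carbon again, with 2-bromo-4-fluorophenyl in place of 3-hydroxyphenyl on a carbon with a double bond to nitrogen. Like compound 1 at 12000 nM, it has no hydroxyl on the phenyl ring, so that single step is the only guide. A move back towards compound 1 is therefore expected in this assay, to a lower number, of about the size of the measured step. The expected change is an at least 6.6-fold lower number from compound 2 to compound 3 (0.82 log units; beyond the scatter). For compound 3 the estimate is 15000 nM, with an expected range of 4000 nM to 60000 nM.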

Compound 3, half-maximal inhibitory concentration: 6590 nM
For compound 3 the middle estimate is 2.3-fold (0.36 log units) above the measured one, and the stated range covers the measured number.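

In this assay this carbon with a double bond to nitrogen proves able to recover the activity lost in compound 2: 2-bromo-4-fluorophenyl in place of 3-hydroxyphenyl gives an at least 15-fold lower number from compound 2 to compound 3 (1.18 log units; beyond the scatter), so the inactivity of compound 2 does not extend to every other substituted phenyl here. The two phenyl groups without a hydroxyl cannot be told apart, with a 1.8-fold lower number from compound 1 to compound 3 (0.26 log units; within the scatter), although one carries halogens and the other methyl groups. Going by these compounds, the size of the step from compound 2 stays open-ended, as the value of compound 2 is a limit of the assay and not a number: the limit of > 100000 nM in this assay, at which 1 of the 3 values shown sits.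

The compounds shown leave open whether the hydroxyl itself matters or its place on the ring. A methoxy group or an amine on the phenyl ring could separate these readings, and an unsubstituted phenyl would give the baseline for all three compounds.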